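This account rests on a few compounds, and the source may have more. Where it says the series, first, only, none or still open, it means among the compounds named here.

Within the data shown here, in a functional assay on A549 cells (Homo sapiens) for antiproliferative activity, read by sulforhodamine B assay, with a stated time of 48 h (a lower number here means a stronger inhibitor, a higher number a weaker inhibitor), compound 1 (`COc1cccc(/C=C/C(=O)/C=C(O)/C=C/c2cccc(OC)c2OC)c1OC`) gives 11500 nM and compound 2 (`COc1cccc(/C=C/C(=O)C(=Cc2ccc(F)cc2)C(=O)/C=C/c2cccc(OC)c2OC)c1OC`) gives 340 nM as the lower of the two numbers so far. Compound 3 (`COc1ccc(C=C(C(=O)/C=C/c2cccc(OC)c2OC)C(=O)/C=C/c2cccc(OC)c2OC)cc1OC`) differs from compound 2 in one place, with 3,4-dimethoxyphenyl in place of 4-fluorophenyl on a double-bonded chain carbon bound to a double-bonded chain carbon as the change. Among the measured compounds shown here, no measured pair isolates this change, so the size of any shift in this assay is uncertain. A modest rise in the number is expected, though a shift no larger than the scatter remains possible. The expected step is a 1.6-fold higher number from compound 2 to compound 3 (0.21 log units; within the scatter) and remains tentative. Compound 3 is estimated at 550 nM with an expected range from 170 nM to 1800 nM for this measurement.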

Compound 3, half-maximal inhibitory concentration: 170 nM
Compound 3: the middle estimate sits 3.2-fold (0.51 log units) above what was measured, within the range that was stated.
By their numbers in this assay, from the lowest: compounds 3 and 2 (each within the scatter of the next); then compound 1.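

On a double-bonded chain carbon bound to a double-bonded chain carbon, 3,4-dimethoxyphenyl in place of 4-fluorophenyl gives a 2.0-fold lower number from compound 2 to compound 3 (0.30 log units; within the scatter) in this assay. This place therefore accepts either aryl group, including the one with hydrogen-bond acceptors, with no step beyond the scatter. No supporting data explain this result.

Still open, going by these compounds, is how this place responds to a group without an aromatic ring, such as a longer alkyl chain. Also open, on these data alone, is whether a phenyl ring carrying an amine or a carboxylic acid keeps the number in this range.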